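Cytotoxicity of a triazole series: all values at the limit

The source may hold more compounds than are shown below. What is called first, only, known or untested is meant among the compounds shown, and "the series" means these compounds.

Measured compounds:
Compound 1 `C=C1C[C@]23C[C@@]1(O)CC[C@H]2c1ccc(OS(=O)(=O)c2ccc(C)cc2)c(C)c1[C@@H]3Cn1cc(-c2ccc(OC)cc2)nn1` in a functional assay on A549 cells (Homo sapiens) for cytotoxicity, read by MTT assay, with a stated time of 4 days (on this read-out lower numbers stand for stronger inhibition and higher numbers for weaker inhibition), gives > 20000 nM.
Compound 2 `C=C1C[C@]23C[C@@]1(O)CC[C@H]2c1ccc(O)c(C)c1[C@@H]3Cn1cc(-c2ccccc2)nn1` gives in this assay > 20000 nM.
Compound 3 `C=C1C[C@]23C[C@@]1(O)CC[C@H]2c1ccc(O)c(C)c1[C@@H]3Cn1cc(-c2ccc(F)cc2)nn1` gives in this assay > 20000 nM.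

Each of these three values is not a number but a limit of this assay, the point beyond which it reports nothing more precise. For compound 3 the value is such a limit. Among the measured compounds shown here, compound 3 therefore stands where every measured compound of this set stands, with no measured member separated from it (the limit of > 20000 nM in this assay, at which 3 of the 3 values shown sit).

Compound 4 `C=C1C[C@]23C[C@@]1(O)CC[C@H]2c1ccc(O)c(C)c1[C@@H]3Cn1cc(-c2ccc(OC)cc2)nn1` has not yet been measured in this assay. It differs from compound 3 in one place: methoxy in place of fluoro on an aromatic carbon of a six-membered aromatic ring of carbon only.

For the measured compounds named here, only one measured step resembles this change, from compound 2 to compound 3 a step that the two limits leave unreadable from compound 2 to compound 3, and its size cannot be read, since both ends are limits. Going by the values given here, no step in this set is readable at all. The expectation for compound 4 therefore rests on the position of the whole set: compound 4 is expected to sit at the same limit, with the step that the limit leaves unreadable from compound 3 to compound 4 estimated as none beyond the scatter. Compound 4 is estimated at 30000 nM, within the range 10000 nM to 100000 nM.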

Compound 4, half-maximal inhibitory concentration: > 20000 nM
Compound 4: a limit, no number (the forecaster's own chance of this, stated with the estimate: 85%); the middle value lies beyond the limit too.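

Compound 4 gives a limit rather than a number, as do compound 1, compound 2 and compound 3, so the steps from each of these to compound 4 cannot be read: the limit of > 20000 nM in this assay, at which 4 of the 4 values shown sit.

The compounds shown leave open how far each one lies past this limit in this assay, and whether any of them differ at all.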